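This account rests on a few compounds, and the source may have more. Where it says the series, first, only, none or still open, it means among the compounds named here.

Compound 3 `CCNc1nc(NCc2ccc(C(=O)Nc3ccc(F)cc3)cc2)c2ccccc2n1` gives 1900 nM in a functional assay on HCT-116 cells (Homo sapiens) for inhibition, read by luminescence and resazurin assay, with a stated time of 3 days (on this read-out lower numbers stand for stronger inhibition and higher numbers for weaker inhibition), the second highest of three numbers. Compound 1 `CCNc1nc(NCc2ccc(NC(=O)c3ccc(F)cc3)cc2)c2ccccc2n1` gives 1400 nM, and the step of a 1.4-fold higher number from compound 1 to compound 3 (0.13 log units; within the scatter) lies within the scatter. Compound 2 `CCCNc1nc(NCc2ccc(C(=O)NCc3ccc(F)cc3)cc2)c2cc(C)ccc2n1` gives 4400 nM, a number beyond the scatter from compound 3, but compound 2 differs from compound 3 in more than one place, so its gap cannot be tied to any single change. Compound 4 `CCCCNc1nc(NCc2ccc(C(=O)Nc3ccc(F)cc3)cc2)c2ccccc2n1` carries ethyl in place of hydrogen on a saturated chain carbon, two bonds along the chain from a nitrogen on an aromatic ring. Among the measured compounds shown here, no measured step touches the length of this chain, so the numbers give no ground to expect a shift beyond the scatter in this assay. Compound 4 is therefore expected to give about 2000 nM, with a range from 700 nM to 6000 nM, an expected step of a 1.1-fold higher number from compound 3 to compound 4 (0.02 log units; within the scatter) that stays within the scatter.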

Compound 4, half-maximal inhibitory concentration: 1400 nM
Compound 4: the middle estimate sits 1.4-fold (0.15 log units) above what was measured, within the range that was stated.
By their numbers in this assay, from the lowest: compounds 1, 4 and 3 (each within the scatter of the next); then compound 2.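

The only single change shown on this chain, ethylamino to butylamino, gives a 1.4-fold lower number from compound 3 to compound 4 (0.13 log units; within the scatter) in this assay. So at this position, adding an ethyl group to the chain leaves the number within the scatter, something the earlier compounds could not show. No available evidence explains this result.

From the compounds shown here alone, it remains open whether a hexyl chain, or a chain ending in an amine or a carboxylic acid, would also stay within the scatter of compound 3. Going by these compounds, it is equally open whether butylamino would behave the same way on compound 1.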